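A few compounds are considered here, and "the series" means these few. Any claim that something is new, unique, unknown or untested is made for them only; others in the source may bear on it.

Measured in a physicochemical assay for solubility, at pH 7.4; on this read-out lower numbers stand for lower solubility and higher numbers for higher solubility:
- compound 1 `CNC1(C)CN(c2c(F)cc3c(=O)c(C(=O)O)cn(C4CC4)c3c2F)C1`: 0.5 ug/mL
- compound 2 `CC1(N)CN(c2c(F)cc3c(=O)c(C(=O)O)cn(C4CC4)c3c2F)C1`: 0.8 ug/mL; 15.3 ug/mL (2 entries)
- compound 3 `C[C@@H]1[C@@H](N(C)C)CN1c1c(F)cc2c(=O)c(C(=O)O)cn(C3CC3)c2c1F`: 97.1 ug/mL

Compound 3 has the highest of the two single numbers in this assay. Its nearest neighbour is compound 1, and the step is a 190-fold higher number from compound 1 to compound 3 (2.29 log units; beyond the scatter). Compound 2 has no single number, as the several entries of compound 2 in this assay, 0.8 ug/mL; 15.3 ug/mL (2 entries) shows, so it gives only a loose reference.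

The next compound is compound 4 `C[C@H]1[C@@H](N)CN1c1c(F)cc2c(=O)c(C(=O)O)cn(C3CC3)c2c1F`. The change is a group of 6 heavy atoms (4 carbon, 2 nitrogen; one four-membered non-aromatic ring with 1 hetero atom) in place of a group of 8 heavy atoms (6 carbon, 2 nitrogen; one four-membered non-aromatic ring with 1 hetero atom), on an aromatic carbon, on an aromatic carbon of a six-membered aromatic ring of carbon only, ortho to two fluoro groups. Among the measured compounds shown here, the only measured step that bears on this group is a 190-fold higher number from compound 1 to compound 3 (2.29 log units; beyond the scatter), which is large and also involves the group on this aromatic carbon. For the measured compounds named here, it shows that a swap at this place can move the number widely, but no measured step matches this exact change. Compound 3 may therefore sit high in the series, and some fall back towards the entries of compound 2 is the likelier direction.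

A drop beyond the scatter is expected, smaller than the step measured from compound 1, and the estimated move is a 6.5-fold lower number from compound 3 to compound 4 (0.81 log units; beyond the scatter). For compound 4 the expected value is 15 ug/mL. The estimated range for compound 4 runs from 2 ug/mL to 100 ug/mL.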

Compound 4, solubility: 23.6 ug/mL
Compound 4: middle estimate off by 1.6-fold (0.20 log units), on the low side; measured number inside the range.
By their numbers in this assay, from the lowest: compound 1; then compound 4; then compound 3.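

In this assay, the swap at this aromatic carbon, ortho to two fluoro groups, now has a second and smaller reading: a 4.1-fold lower number from compound 3 to compound 4 (0.61 log units; beyond the scatter). Compound 4, with the group of 6 heavy atoms, still stands well clear of compound 1, with a 47-fold higher number from compound 1 to compound 4 (1.67 log units; beyond the scatter), so a large rise at this place does not require the group of 8 heavy atoms. The order of the numbers does not follow the heavy-atom count of the group, since compound 1, with its group of 7 heavy atoms, is the lowest of the three, and compound 2 stays outside this order: the several entries of compound 2 in this assay, 0.8 ug/mL; 15.3 ug/mL (2 entries)

What separates compound 1 from compound 4 remains unresolved, as the two groups differ in the arrangement of their atoms as well as in size, and no pair shown isolates a single feature of the group. From the compounds shown here alone, how an ethyl chain on the nitrogen or a hydroxyl group in place of the amine would read at this aromatic carbon also stays open, and the size of these steps may not carry over to such groups.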